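This account rests on a few compounds, and the source may have more. Where it says the series, first, only, none or still open, it means among the compounds named here.

Measured in an assay on CHO cells for displacement of a labelled ligand from adenosine receptor A3 (Homo sapiens), read by scintillation counting, with a stated time of 120 min, tested at 10 uM; a higher number here means more inhibition at the concentration tested (going by the name of the read-out), a lower number less inhibition:
compound 1 `Nc1scc(CN2CCN(c3ccc(Cl)cc3Cl)CC2)c1C(=O)c1ccc(Cl)cc1` gives 0%;
compound 2 `Nc1scc(CN2CCN(C3CCCC3)CC2)c1C(=O)c1ccc(Cl)cc1` gives 3%;
compound 3 `Nc1scc(CN2CCN(c3ccccc3F)CC2)c1C(=O)c1ccc(Cl)cc1` gives 0%.

Compound 3 stands level with compound 1, the two together the lowest of the three numbers. Its nearest neighbour is compound 1, with no change at the digits printed from compound 1 to compound 3 (within the scatter); its furthest is compound 2, with a number 3 percentage points lower from compound 2 to compound 3 (within the scatter). Compound 4 is `Nc1scc(CN2CCN(c3ccc(F)c(Cl)c3)CC2)c1C(=O)c1ccc(Cl)cc1`, and the change from compound 3 is 3-chloro-4-fluorophenyl in place of 2-fluorophenyl on an amine nitrogen in a ring. Within the data shown here, the steps that bear on it are the three swaps of the group on the same ring nitrogen: a number 3 percentage points higher from compound 1 to compound 2 (within the scatter), no change at the digits printed from compound 1 to compound 3 (within the scatter) and a number 3 percentage points lower from compound 2 to compound 3 (within the scatter), all of them within the scatter. No step beyond the scatter is therefore expected in this assay for compound 4, in either direction. Compound 4 is estimated at 2%, in the range 0% to 12%, which means an expected step of a number 2 percentage points higher from compound 3 to compound 4 (within the scatter).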

Compound 4, a percentage reported as inhibition, at one concentration (the size of the read-out at that concentration, not a potency): 0%
Beside the measured number, compound 4's estimate is 2 percentage points above it, within the range that was stated.
By their numbers in this assay, from the lowest: compounds 1, 3, 4 and 2 (each within the scatter of the next).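

In this assay, placing 3-chloro-4-fluorophenyl on the amine nitrogen in the ring gives no change at the digits printed from compound 3 to compound 4 (within the scatter) and a number 3 percentage points lower from compound 2 to compound 4 (within the scatter) and also no change at the digits printed from compound 1 to compound 4 (within the scatter). This position has now taken a third halogen-bearing phenyl group, alongside the cyclopentyl group, with no step beyond the scatter. Nothing available explains these readings. As far as these compounds go, whether a benzyl group, an acyl group or a longer alkyl chain on this nitrogen would read differently remains open. So does whether a carboxylic acid or an amine elsewhere on the shared core would change the picture.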